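A few compounds are considered here, and "the series" means these few. Any claim that something is new, unique, unknown or untested is made for them only; others in the source may bear on it.

Measured so far, in a functional assay on CHO cells for activation of 5-hydroxytryptamine receptor 1D (Homo sapiens), read by GTPgammaS binding; on this read-out lower numbers stand for smaller maximal responses and higher numbers for larger maximal responses:
compound 1, `CN(Cc1cccs1)C1CCN(CCCc2c[nH]c3ccc(-n4cnnc4)cc23)CC1`, gives 81%
compound 2, `COC[C@H](NC1CCN(CCCc2c[nH]c3ccc(-n4cnnc4)cc23)CC1)c1ccccc1`, gives 93%
compound 3, `c1cc(CNC2CCN(CCCc3c[nH]c4ccc(-n5cnnc5)cc34)CC2)co1`, gives 65%

Compound 3 has the lowest of these three numbers: the gaps are a number 16 percentage points lower from compound 1 to compound 3 (beyond the scatter) and a number 28 percentage points lower from compound 2 to compound 3 (beyond the scatter), both beyond the scatter. Compound 4, `OCCC(NC1CCN(CCCc2c[nH]c3ccc(-n4cnnc4)cc23)CC1)c1ccccc1`, differs from compound 3 by 3-hydroxy-1-phenylpropyl in place of (furan-3-yl)methyl on an amine nitrogen. The step that bears on this is a number 28 percentage points lower from compound 2 to compound 3 (beyond the scatter), where a chain carrying a six-membered aromatic ring of carbon only was replaced by the (furan-3-yl)methyl group. Compound 4 brings such a chain back, so an upward step of similar size is expected, namely a number 20 percentage points higher from compound 3 to compound 4 (beyond the scatter). Compound 4 is therefore estimated at 85%, within a range from 70% to 98%.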

Compound 4, largest response reached (reported as efficacy), in percent of the reference or control that the assay uses: 100%
Compound 4: middle estimate off by 15 percentage points, on the low side, outside the stated range (above it).
By their numbers in this assay, from the lowest: compound 3; then compound 1; then compounds 2 and 4 (each within the scatter of the next).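

On the amine nitrogen, 3-hydroxy-1-phenylpropyl in place of (furan-3-yl)methyl gives a large rise in this assay, with a number 35 percentage points higher from compound 3 to compound 4 (beyond the scatter) as the step. Two differently built chains with a six-membered aromatic ring now sit level, with a number 7 percentage points higher from compound 2 to compound 4 (within the scatter) as their step, and the step of a number 19 percentage points higher from compound 1 to compound 4 (beyond the scatter) puts 3-hydroxy-1-phenylpropyl clear of the methylated thiophene amine as well. Nothing measured here explains why these steps arise.

As far as these compounds go, it stays open whether the ring or the hydroxyl chain matters more. A plain benzyl group or a 3-amino-1-phenylpropyl chain on this nitrogen would help separate the two.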